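Chain shortening at the carbamate in a selenocyanate series

The compounds below may be only part of what the source reports. "The series", "measured", "known", "first", "only" and "open" are said of these compounds alone.

Measured so far in a functional assay on CCRF-CEM cells (Homo sapiens) for cytotoxicity, read by MTT assay, with a stated time of 72 h; on this read-out higher numbers stand for weaker inhibition of growth and lower numbers for stronger inhibition of growth:
compound 1, `COc1ccc(OC(=O)Nc2ccc([Se]C#N)cc2)cc1`, 13000 nM
compound 2, `CCCOC(=O)Nc1ccc([Se]C#N)cc1`, 9300 nM
compound 3, `Cc1ccc(OC(=O)Nc2ccc([Se]C#N)cc2)cc1`, 17400 nM

Compound 2 gives the lowest of the three numbers in this assay, yet its separation from compound 1 and from compound 3 is within the scatter, so no order among the three can be claimed. Among the measured compounds shown here, the only step between measured compounds is a 1.3-fold higher number from compound 1 to compound 3 (0.13 log units; within the scatter), a change on the aromatic ring of the aryl carbamates; it does not touch the carbamate chain and says little about the step under consideration.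

Compound 4, `CCOC(=O)Nc1ccc([Se]C#N)cc1`, differs from compound 2 by hydrogen in place of methyl on a saturated chain carbon, two bonds along the chain from an oxygen next to a carbonyl group. For the measured compounds named here, no measured pair covers a change of this kind, so the expectation rests on the general observation that all three carbamates, aryl or alkyl, sit within the scatter of one another in this assay. On that basis compound 4 is expected to stay close to compound 2, with a 1.0-fold higher number from compound 2 to compound 4 (0.01 log units; within the scatter) as the estimated step. For compound 4 the value in this assay is estimated at 9500 nM, in a range from 4000 nM to 23000 nM.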

Compound 4, concentration for 50% growth inhibition: 9800 nM
Beside the measured number, compound 4's estimate is 1.0-fold (0.01 log units) below it; measured number inside the range.
By their numbers in this assay, from the lowest: compounds 2, 4, 1 and 3 (each within the scatter of the next).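

Among the compounds shown here, the step of a 1.1-fold higher number from compound 2 to compound 4 (0.02 log units; within the scatter) in this assay is the first reading taken on the carbamate chain itself, and it lies within the scatter. Propyl to ethyl, with hydrogen in place of methyl on a saturated chain carbon, two bonds along the chain from an oxygen next to a carbonyl group, gives no separable difference in this assay, whereas the earlier step touched only the aromatic ring of the aryl carbamates and could not speak to this position. Nothing available here bears on why this change leaves the read-out within the scatter, and no reason can be offered.

As far as these compounds go, whether this flat reading extends further along the chain stays open, since a methyl carbamate, a longer chain such as hexyl or a branched chain such as isopropyl could still separate from compound 2 and compound 4. For the compounds shown here, a chain bearing an amine or a carboxylic acid is equally open, and the one step at this position does not show how large a change the carbamate chain can take before the number moves beyond the scatter.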